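A few compounds are considered here, and "the series" means these few. Any claim that something is new, unique, unknown or untested is made for them only; others in the source may bear on it.

Compound 3 `Cc1nc(NC(C)(C)C)nc(N[C@@H]2C[C@H](CO)[C@@H](O)[C@H]2O)c1-c1nc2ccccc2s1` is the only one of the three measured compounds to give a number in an ADME assay on cells (Homo sapiens) for cytotoxicity, read by polymerase chain reaction, with a stated time of 3 days; a lower number here means that less compound is tolerated, a higher number that more compound is tolerated: in this assay compound 3 gives 12000 nM. Compound 1 `Nc1nc(Cl)c(-c2cccs2)c(N[C@@H]2C[C@H](CO)[C@@H](O)[C@H]2O)n1` gives only a limit, > 25000 nM. Compound 2 `Nc1nc(Cl)c(-c2ncco2)c(N[C@@H]2C[C@H](CO)[C@@H](O)[C@H]2O)n1` likewise gives only a limit, > 25000 nM. The step that the two limits leave unreadable from compound 1 to compound 2 is therefore unreadable, because both values sit at the limit of > 25000 nM in this assay, at which 2 of the 3 values shown sit. Compound 4 `Cc1nc(NCCOC(C)C)nc(N[C@@H]2C[C@H](CO)[C@@H](O)[C@H]2O)c1-c1nc2ccccc2s1` differs from compound 3 by 2-isopropoxyethyl in place of tert-butyl on a nitrogen on an aromatic ring. Within the data shown here, no measured step changes the group on that nitrogen, and the one measured step is unreadable, so nothing here points in either direction beyond the scatter. The expected change in this assay is a 1.2-fold higher number from compound 3 to compound 4 (0.07 log units; within the scatter), that is, nothing beyond the scatter. Compound 4 is therefore estimated at 14000 nM, within 6000 nM to 30000 nM.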

Compound 4, half-maximal cytotoxic concentration: 8000 nM
Estimate against measurement, compound 4: 1.8-fold (0.24 log units) above, and the stated range covers the measured number.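

This is the first readable step among the compounds shown, and it falls on the nitrogen on an aromatic ring: in this assay, 2-isopropoxyethyl in place of tert-butyl gives a 1.5-fold lower number from compound 3 to compound 4 (0.18 log units; within the scatter). Exchanging the branched tert-butyl for this longer, oxygen-bearing chain therefore moves the number no further than the scatter. Nothing shown gives a reason for this step.

From the compounds shown here alone, whether an amine or a carboxylic acid on that chain would move the number beyond the scatter stays open. Going by these compounds, the step from compound 1 to compound 2 still cannot be read, so the effect of the group on the aromatic carbon also stays open.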